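This account rests on a few compounds, and the source may have more. Where it says the series, first, only, none or still open, it means among the compounds named here.

Measured so far in an ADME assay on isolated protein for inhibition of Dihydrofolate reductase (Homo sapiens), using NADPH; a higher number here means a weaker inhibitor, a lower number a stronger inhibitor:
- compound 1 `CN(c1ccccc1)c1ccc2nc(N)nc(N)c2n1`: 942 nM
- compound 2 `CCCN(c1ccccc1)c1ccc2nc(N)nc(N)c2n1`: 1340 nM
- compound 3 `CC(C)N(c1ccccc1)c1ccc2nc(N)nc(N)c2n1`: 1370 nM

Compound 3 sits at the top of these three numbers, yet its separation from the others is slight: a 1.5-fold higher number from compound 1 to compound 3 (0.16 log units; within the scatter) and a 1.0-fold higher number from compound 2 to compound 3 (0.01 log units; within the scatter) both lie within the scatter, as does a 1.4-fold higher number from compound 1 to compound 2 (0.15 log units; within the scatter). Compound 4 `CCCCN(c1ccccc1)c1ccc2nc(N)nc(N)c2n1` has not yet been measured in this assay. It differs from compound 3 in one place: butyl in place of isopropyl on a nitrogen on an aromatic ring. Among the compounds with values here, the steps that bear on this change are those among compounds 1, 2 and 3, where methyl, propyl and isopropyl were exchanged on the same nitrogen on an aromatic ring; none of them moved the number beyond the scatter. Lengthening to butyl is of the same kind, so no step beyond the scatter is expected in this assay, with at most a slight drift toward a weaker inhibitor. Compound 4 is therefore estimated at 1500 nM, between 800 nM and 2900 nM, which corresponds to an expected step of a 1.1-fold higher number from compound 3 to compound 4 (0.04 log units; within the scatter).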

Compound 4, half-maximal inhibitory concentration: 903 nM
Estimate against measurement, compound 4: 1.7-fold (0.22 log units) above; the range from low to high includes it.
By their numbers in this assay, from the lowest: compounds 4, 1, 2 and 3 (each within the scatter of the next).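

In this assay, butyl on the nitrogen on an aromatic ring adds a fourth chain to the series without any step leaving the scatter: a 1.5-fold lower number from compound 3 to compound 4 (0.18 log units; within the scatter), a 1.5-fold lower number from compound 2 to compound 4 (0.17 log units; within the scatter) and a 1.0-fold lower number from compound 1 to compound 4 (0.02 log units; within the scatter). Methyl, propyl, isopropyl and butyl therefore cannot be told apart at this position in this assay, and the exchange of isopropyl for butyl, with its one further carbon, shows no step beyond the scatter. Nothing available explains why these chains read alike.

On these data alone, it remains open whether a much longer chain such as octyl, or a chain carrying an amine or a carboxylic acid, would move the number beyond the scatter at this nitrogen.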